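The compounds below may be only part of what the source reports. "The series", "measured", "known", "first", "only" and "open" are said of these compounds alone.

Measured so far in an assay on cells for antagonist activity at transient receptor potential cation channel subfamily V member 1 (Homo sapiens), read by FLIPR and calcium flux, with a stated time of 6 min; a higher number here means a weaker inhibitor, a lower number a stronger inhibitor:
- compound 1 `CC(C(=O)NCc1ccc(C(C)(C)C)nc1N1CCCC1)c1ccc(NS(C)(=O)=O)c(F)c1`: 1.2 nM
- compound 2 `CC(C)CCOc1nc(C(C)(C)C)ccc1CNC(=O)C(C)c1ccc(NS(C)(=O)=O)c(F)c1`: 0.8 nM
- compound 3 `CC(C(=O)NCc1ccc(C(C)(C)C)nc1SCc1ccccc1)c1ccc(NS(C)(=O)=O)c(F)c1`: 4 nM

Compound 3 stands highest of the three numbers; the steps of a 3.3-fold higher number from compound 1 to compound 3 (0.52 log units; beyond the scatter) and a 5.0-fold higher number from compound 2 to compound 3 (0.70 log units; beyond the scatter) are both beyond the scatter, while a 1.5-fold lower number from compound 1 to compound 2 (0.18 log units; within the scatter) is within it. Compound 4 `CC(C(=O)NCc1ccc(C(C)(C)C)nc1SCc1ccccc1Cl)c1ccc(NS(C)(=O)=O)c(F)c1` differs from compound 3 by chloro in place of hydrogen on an aromatic carbon. Among the compounds with values here, none of the measured steps touches the benzyl ring of the benzylsulfanyl group: the steps into compound 3 exchange the whole group on the aromatic carbon of the core and carry no information on a chloro placed on that ring. With nothing to support a change in either direction, the expected step of no change at the digits printed from compound 3 to compound 4 (within the scatter) is none beyond the scatter. Compound 4 is estimated at 4 nM, range 1.5 nM to 11 nM.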

Compound 4, inhibition constant: 3.8 nM
The estimate for compound 4 lay 1.1-fold (0.02 log units) above the measured number; low and high end bracket the measured number.
By their numbers in this assay, from the lowest: compounds 2 and 1 (each within the scatter of the next); then compounds 4 and 3 (each within the scatter of the next).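

In this assay, chloro in place of hydrogen on the benzyl ring of the benzylsulfanyl group gives a 1.1-fold lower number from compound 3 to compound 4 (0.02 log units; within the scatter), so this ring carbon accepts a chloro with no change beyond the scatter. The gaps to the other groups on the core remain, with a 4.8-fold higher number from compound 2 to compound 4 (0.68 log units; beyond the scatter) and a 3.2-fold higher number from compound 1 to compound 4 (0.50 log units; beyond the scatter), both beyond the scatter. No evidence available bears on this result.

On these data alone, whether a methoxy, an amine or a carboxylic acid on this ring would behave like chloro stays open. So does the effect of a longer chain in place of the benzyl group.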